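The source may report more compounds than this note shows. Statements on the series, on what has been measured and on what is new or still open speak of the compounds shown alone.

In an ADME assay on HEK293 cells (Homo sapiens) for cytotoxicity, read by CCK-8 assay, with a stated time of 48 h (a higher number here means a weaker inhibitor, a lower number a stronger inhibitor), each value below is a limit of the assay and not a number:
Compound 1 `COc1ccc(/C=C\c2cc(OC)c(OC)c(OC)c2)cc1OCc1ccc(CNC(C)(C)C(=O)O)cc1` gives > 50000 nM (limit)
Compound 2 `COc1ccc(/C=C\c2cc(OC)c(OC)c(OC)c2)cc1OCc1ccc(CNCCO)cc1` gives > 50000 nM (limit)
Compound 3 `COc1ccc(/C=C\c2cc(OC)c(OC)c(OC)c2)cc1OCc1ccc(CN2CC(C(=O)O)C2)cc1` gives > 50000 nM (limit)

Compound 3 therefore has only a limit and no measured number. Compound 4 (`COc1ccc(/C=C\c2cc(OC)c(OC)c(OC)c2)cc1OCc1ccc(CNCCNC(C)=O)cc1`) carries (2-acetamidoethyl)amino in place of 3-carboxyazetidin-1-yl on a saturated chain carbon bound to an aromatic carbon. Within the data shown here, three measured steps bear on this change (a step that the two limits leave unreadable from compound 1 to compound 3; a step that the two limits leave unreadable from compound 2 to compound 3; a step that the two limits leave unreadable from compound 1 to compound 2) and none has a readable size. Going by compound 2 and compound 3, no step beyond the scatter is expected in this assay because of a step that the two limits leave unreadable from compound 2 to compound 3 and the limit of > 50000 nM in this assay, at which 3 of the 3 values shown sit, taken together. The expected step (a number no higher from compound 3 to compound 4 (the limit leaves the size open)) is accordingly small. Compound 4 is estimated at 50000 nM within a range from 20000 nM to 100000 nM and is expected to read as a limit again.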

Compound 4, half-maximal inhibitory concentration: > 50000 nM
Compound 4 ended at the assay's limit (the forecaster's own chance of this, stated with the estimate: 85%); the middle value sits exactly at the limit.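

No step among compound 1, compound 2, compound 3 and compound 4 can be read in this assay, because all four stop at one limit: the limit of > 50000 nM in this assay, at which 4 of the 4 values shown sit.

The compounds shown leave open whether these four differ in cytotoxicity at all.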